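Removing a Chloro Group from a Fused Two-Ring Core

The source may hold more compounds than are shown below. What is called first, only, known or untested is meant among the compounds shown, and "the series" means these compounds.

Of the compounds shown here, three sharing a two-ring core have been tested in a functional assay on M14 cells (Homo sapiens) for cytotoxicity, read by sulforhodamine B assay, with a stated time of 48 h; on this read-out lower numbers stand for stronger inhibition of growth and higher numbers for weaker inhibition of growth. Compound 1 `ClCc1cccc(Cn2cnc3ncnc(Cl)c32)c1` gives 14500 nM. Compound 2 `ClCc1ccc(Cn2cnc3nc(Cl)nc(Cl)c32)cc1` gives 3160 nM, and compound 3 `ClCc1cccc(Cn2cnc3nc(Cl)nc(Cl)c32)c1` gives 2630 nM. Compound 2 and compound 3 are made of the same atoms joined differently; the difference between their two cores is not broken down here, and their numbers lie within the usual scatter of each other, so no order can be drawn between them.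

Compound 3 and compound 1 differ in a single place: hydrogen in place of chloro on an aromatic carbon This change produced a 5.5-fold higher number from compound 3 to compound 1 (0.74 log units; beyond the scatter), meaning the compound that lost the chloro group needed a clearly higher concentration to halt growth.

Compound 4 `ClCc1ccc(Cn2cnc3ncnc(Cl)c32)cc1` has not yet been measured. It relates to compound 2 as compound 1 relates to compound 3: hydrogen in place of chloro on an aromatic carbon The surroundings of the changed carbon are described in identical words for both pairs, so this is the same change applied to a different starting compound.

The expectation rests on two things: the earlier step, which was a 5.5-fold higher number from compound 3 to compound 1 (0.74 log units; beyond the scatter), and the starting point, where compound 2 gives 3160 nM. On that basis the expected step is a 4.7-fold higher number from compound 2 to compound 4 (0.68 log units; beyond the scatter). Among the compounds with values here, compound 4 is therefore expected to give about 15000 nM, most likely falling somewhere from 6000 nM to 40000 nM, with only one prior example to support this.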

Compound 4, concentration for total growth inhibition: 13200 nM
Beside the measured number, compound 4's estimate is 1.1-fold (0.06 log units) above it; the range from low to high includes it.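

Swapping the chloro group for hydrogen on the carbon between two ring nitrogen atoms gave, in this assay, a 4.2-fold higher number from compound 2 to compound 4 (0.62 log units; beyond the scatter), so compound 4 needs a clearly higher concentration than its chlorinated partner to halt growth. Within the data shown here, the same swap on the other core gave a step of matching size, so in this small series the change carried across from one core to the other: the same change on two cores in this assay, a 5.5-fold higher number (0.74 log units; beyond the scatter) from compound 3 to compound 1 and a 4.2-fold higher number (0.62 log units; beyond the scatter) from compound 2 to compound 4, 1.3-fold (0.12 log units) apart, within the scatter of two such steps This agreement rests on only two pairs of compounds in a single cell assay, so it does not show that the step would hold on other cores or in other cells, and it does not explain why losing this chloro group weakens growth inhibition.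

On these data alone, all four compounds carry either hydrogen or chloro on that carbon, so it remains open how an amine, a methoxy group or a longer chain would behave there. As far as these compounds go, all four also keep the chloromethyl group and the second chloro group on the shared core, so what a plain methyl or a hydroxymethyl group in place of the chloromethyl group would do also stays unknown.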